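Swapping the aryl substituent on a shared pyrazolopyridine core

The compounds below may be only part of what the source reports. "The series", "measured", "known", "first", "only" and "open" are said of these compounds alone.

Measured so far:
compound 1, `CCCS(=O)(=O)Nc1ccc(F)c(C(=O)c2n[nH]c3ncc(-c4ccc(F)cc4)cc23)c1F`: 2.1%
compound 2, `CCCS(=O)(=O)Nc1ccc(F)c(C(=O)c2n[nH]c3ncc(-c4ccc(Cl)cc4Cl)cc23)c1F`: 22%

In an assay for binding affinity to dual specificity mitogen-activated protein kinase kinase 4 (Homo sapiens), read by KINOMEscan, tested at 100 nM (on this read-out higher numbers stand for a weaker effect at the one concentration tested and lower numbers for a stronger effect), compound 1 gives 2.1%, while compound 2 gives 22%. For the measured compounds named here, compound 2 thus stands at the higher, weaker end of these two numbers, and the only measured step, a number 19.9 percentage points higher from compound 1 to compound 2 (beyond the scatter), is the one that separates them.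

Compound 3, `CCCS(=O)(=O)Nc1ccc(F)c(C(=O)c2n[nH]c3ncc(-c4ccc(C(C)C)cc4)cc23)c1F`, is the next compound to be measured. Its change from compound 2 is 4-isopropylphenyl in place of 2,4-dichlorophenyl on an aromatic carbon. Going by the values given here, no measured step covers this exact exchange. Among the compounds with values here, the single available step shows that moving away from 4-fluorophenyl to 2,4-dichlorophenyl weakened the effect modestly; compound 3 carries a single group on the phenyl ring again, as compound 1 does, but a different one. The step back toward lower numbers that is therefore expected, with wide uncertainty, is an estimated a number 12 percentage points lower from compound 2 to compound 3 (beyond the scatter). Compound 3 is estimated at 10%, within 1% to 40%.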

Compound 3, a percentage reported as activity, at one concentration (the size of the read-out at that concentration, not a potency): 17%
Beside the measured number, compound 3's estimate is 7 percentage points below it; the measured number falls inside the stated range.
By their numbers in this assay, from the lowest: compound 1; then compounds 3 and 2 (each within the scatter of the next).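

In this assay, 4-isopropylphenyl in place of 2,4-dichlorophenyl gives a number 5 percentage points lower from compound 2 to compound 3 (within the scatter) and so does not separate these two groups at this position, although they differ in what the phenyl ring carries. Going back to a single group on the phenyl ring is therefore not enough to recover the low number of compound 1, as isopropyl in place of fluoro gives a number 14.9 percentage points higher from compound 1 to compound 3 (beyond the scatter) and the 4-fluorophenyl group remains the only one of the three beyond the scatter of the others.

Going by these compounds, it remains open how a 4-chlorophenyl group, with one chlorine alone, would compare with these three, and whether a phenyl ring carrying an amine or a carboxylic acid would be tolerated at this position. No separate measurement bears on why the numbers fall as they do.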